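Removing One Chloro Group from a Dichloro Core

The source may hold more compounds than are shown below. What is called first, only, known or untested is meant among the compounds shown, and "the series" means these compounds.

Measured compounds:
compound 1, `ClCc1ccc(Cn2cnc3c(Cl)ncnc32)cc1` — > 100000 nM
compound 2, `ClCc1ccc(Cn2cnc3nc(Cl)nc(Cl)c32)cc1` — 38000 nM

In a functional assay on NCI-H522 cells (Homo sapiens) for cytotoxicity, read by sulforhodamine B assay, with a stated time of 48 h (on this read-out higher numbers stand for lower toxicity in this test and lower numbers for higher toxicity in this test), compound 1 reaches only a limit of the assay, > 100000 nM. Among the measured compounds shown here, compound 2 is the one compound with a number, 38000 nM in this assay. For the measured compounds named here, the one further value, that of compound 1, is a limit (the limit of > 100000 nM in this assay, at which 1 of the 2 values shown sits). Compound 3, `ClCc1ccc(Cn2cnc3ncnc(Cl)c32)cc1`, differs from compound 2 by hydrogen in place of chloro on an aromatic carbon. Going by the values given here, no step between measured compounds is available, so the size of this step is uncertain; a loss of toxicity beyond the scatter is expected, with a 2.4-fold higher number from compound 2 to compound 3 (0.37 log units; beyond the scatter). Compound 3 is thus estimated at 90000 nM, between 30000 nM and 250000 nM.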

Compound 3, concentration lethal to 50% of the cells: > 100000 nM
Compound 3: a limit, no number (the forecaster's own chance of this, stated with the estimate: 50%); at least 1.1-fold (0.04 log units) between middle value and limit.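

In this assay, among the compounds shown here, replacing the chloro group with hydrogen on the aromatic carbon between two ring nitrogen atoms gives an at least 2.6-fold higher number from compound 2 to compound 3 (0.42 log units; beyond the scatter), the first measured step at this position. Compound 3 reaches only a limit of the assay, > 100000 nM. The full size of the step therefore cannot be read, and only the dichloro compound 2 keeps a number: the limit of > 100000 nM in this assay, at which 2 of the 3 values shown sit.

On these data alone, what a methyl, an amine or a methoxy group on this carbon would do remains open. So does whether any group other than chloro here would give a number at all.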